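From propanoyl to vinylcarbonyl on a shared core

A few compounds are considered here, and "the series" means these few. Any claim that something is new, unique, unknown or untested is made for them only; others in the source may bear on it.

In a functional assay on MV4-11 cells (Homo sapiens) for inhibition, read by WST assay, with a stated time of 4 days (a higher number here means a weaker inhibitor, a lower number a stronger inhibitor), compound 1 `CC(C)(C)c1ccc(CN2CCN(S(=O)(=O)Nc3ccc(SCCc4ccccc4)cc3C(=O)O)CC2)cc1` gives 20800 nM as its half-maximal inhibitory concentration. Compound 2 `CCC(=O)N1CCN(c2c3ccc(-c4cccc(F)c4)cc3nn2Cc2ccccc2)CC1` gives 8900 nM as the lower of the two numbers, and the gap between them lies beyond the usual scatter. Compound 3 `C=CC(=O)N1CCN(c2c3ccc(-c4cccc(F)c4)cc3nn2Cc2ccccc2)CC1` departs from compound 2 at one place, with vinyl in place of ethyl on a carbonyl carbon, so that propanoyl becomes vinylcarbonyl. The counted difference vinyl in place of ethyl on a carbonyl carbon is the whole of the change. For the measured compounds named here, no measured pair here differs in one place, so the data offer no direct guide to this swap. A moderate move toward stronger inhibition in this assay is nevertheless expected, an estimated 3.0-fold lower number from compound 2 to compound 3 (0.47 log units; beyond the scatter) that would lie beyond the scatter. For compound 3 the estimated value is 3000 nM with 700 nM to 10000 nM as the expected range.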

Compound 3, half-maximal inhibitory concentration: 3900 nM
The estimate for compound 3 lay 1.3-fold (0.11 log units) below the measured number; measured number inside the range.
By their numbers in this assay, from the lowest: compound 3; then compound 2; then compound 1.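

For the compounds shown here, exchanging the propanoyl group for vinylcarbonyl, on a carbonyl carbon whose other neighbour is an amide-type nitrogen in a ring, gives, in this assay, a 2.3-fold lower number from compound 2 to compound 3 (0.36 log units; beyond the scatter) and provides the first comparison here between compounds that differ in one place. The step is modest but lies beyond the usual scatter, so this position does respond to the change, and the counted difference between the two groups is the double bond outside aromatic rings. Nothing measured here accounts for the step.

The compounds shown leave open how a longer chain such as butanoyl, a propynoyl group with its triple bond, or a butenoyl chain carrying a dimethylamino group would read on the same carbonyl carbon. They also leave open whether the same swap would give a similar step on another core.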